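Replacing 4-fluorophenyl with 1-methyl-1H-pyrrol-2-yl on the shared core

The source may hold more compounds than are shown below. What is called first, only, known or untested is meant among the compounds shown, and "the series" means these compounds.

- compound 1 `Cc1csc(-c2ncnc3c2ncn3C2O[C@H](CO)[C@@H](O)[C@H]2O)c1`: 5600 nM
- compound 2 `OC[C@H]1OC(n2cnc3c(-c4ccc(F)cc4)ncnc32)[C@H](O)[C@@H]1O`: 6300 nM

In a functional assay on HL-60 cells (Homo sapiens) for inhibition (on this read-out higher numbers stand for weaker inhibition and lower numbers for stronger inhibition), compound 2 gives 6300 nM, which lies within the scatter of compound 1 at 5600 nM. Compound 3 `Cn1cccc1-c1ncnc2c1ncn2C1O[C@H](CO)[C@@H](O)[C@H]1O` carries 1-methyl-1H-pyrrol-2-yl in place of 4-fluorophenyl on an aromatic carbon. For the measured compounds named here, only one measured step bears on this change, a 1.1-fold higher number from compound 1 to compound 2 (0.05 log units; within the scatter), and it exchanged groups at the same place. That is thin evidence, but it points to no step beyond the scatter in this assay. The expected change is a 1.3-fold lower number from compound 2 to compound 3 (0.10 log units; within the scatter). For compound 3 the estimate is 5000 nM, with an expected range of 1500 nM to 17000 nM.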

Compound 3, half-maximal inhibitory concentration: 15700 nM
Compound 3: middle estimate off by 3.1-fold (0.50 log units), on the low side; the range from low to high includes it.
By their numbers in this assay, from the lowest: compounds 1 and 2 (each within the scatter of the next); then compound 3.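

In this assay the group on this aromatic carbon turns out to matter, which the earlier swap did not show: 1-methyl-1H-pyrrol-2-yl gives a 2.5-fold higher number from compound 2 to compound 3 (0.40 log units; beyond the scatter) and also a 2.8-fold higher number from compound 1 to compound 3 (0.45 log units; beyond the scatter) and so inhibits less well than either earlier group. Ring size alone does not sort these results, since 4-methylthiophen-2-yl in compound 1 is also a five-membered ring. Nothing measured here says why the number rises.

Open, on these data alone, is how an amine, a carboxylic acid or a longer chain at this position would behave, and whether any group here can give stronger inhibition than compound 1 and compound 2.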